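Arylthio variation on the shared core: trifluoromethyl analogue

The source may hold more compounds than are shown below. What is called first, only, known or untested is meant among the compounds shown, and "the series" means these compounds.

Compound 3 `Cc1cc(Nc2cc(-c3ccccc3)[nH]n2)n2nc(SCCc3ccccc3)nc2n1` gives 5620 nM in a functional assay on MGC-803 cells (Homo sapiens) for inhibition, read by MTT assay, with a stated time of 72 h; on this read-out higher numbers stand for weaker inhibition and lower numbers for stronger inhibition. Compound 2 `Cc1cc(Nc2cc(-c3ccccc3)[nH]n2)n2nc(SCc3c(Cl)cccc3Cl)nc2n1` gives 5280 nM and compound 1 `Cc1cc(Nc2cc(-c3ccccc3)[nH]n2)n2nc(SCc3ccc([N+](=O)[O-])cc3)nc2n1` gives 4250 nM; all three numbers sit within the scatter of one another, as the steps of a 1.2-fold higher number from compound 1 to compound 2 (0.09 log units; within the scatter), a 1.3-fold higher number from compound 1 to compound 3 (0.12 log units; within the scatter) and a 1.1-fold higher number from compound 2 to compound 3 (0.03 log units; within the scatter) show. Compound 4 `Cc1cc(Nc2cc(-c3ccccc3)[nH]n2)n2nc(SCc3ccc(C(F)(F)F)cc3)nc2n1` carries 4-(trifluoromethyl)phenyl in place of benzyl on a saturated chain carbon bound to a sulfur. Every measured exchange of the group on a saturated chain carbon bound to a sulfur has stayed within the scatter, so the change from benzyl to 4-(trifluoromethyl)phenyl is not expected to move the number beyond it either. Compound 4 is therefore estimated at 5000 nM, within 2500 nM to 10000 nM, an expected step of a 1.1-fold lower number from compound 3 to compound 4 (0.05 log units; within the scatter).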

Compound 4, half-maximal inhibitory concentration: 3520 nM
Compound 4: middle estimate off by 1.4-fold (0.15 log units), on the high side; low and high end bracket the measured number.
By their numbers in this assay, from the lowest: compounds 4, 1, 2 and 3 (each within the scatter of the next).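

In this assay the 4-(trifluoromethyl)phenyl group stays within the scatter against all three earlier groups, with a 1.6-fold lower number from compound 3 to compound 4 (0.20 log units; within the scatter) and a 1.5-fold lower number from compound 2 to compound 4 (0.18 log units; within the scatter) and a 1.2-fold lower number from compound 1 to compound 4 (0.08 log units; within the scatter) as the steps. The last of these adds a direct exchange on an aromatic carbon, trifluoromethyl for nitro, and the two cannot be told apart here. No measurement available explains this flat response.

Open, as far as these compounds go, is whether a carboxylic acid, an amine or a longer chain on the sulfur would move the number beyond the scatter. Also open, from the compounds shown here alone, is whether any change elsewhere on the shared core would do so.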